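This account rests on a few compounds, and the source may have more. Where it says the series, first, only, none or still open, it means among the compounds named here.

Measured so far:
- compound 1 `C=C[C@@](C)(/C=C/c1ccc(O)cc1)CCC(O)C(C)(C)O`: > 36600 nM
- compound 2 `C=C[C@@](C)(/C=C/c1ccc(O)cc1)CCCO`: > 36600 nM
- compound 3 `C=C[C@@](C)(/C=C/c1ccc(O)c(/C=C/C#N)c1)CCC=C(C)C`: > 36600 nM

In an ADME assay on HEK293 cells (Homo sapiens) for cytotoxicity, with a stated time of 72 h (a higher number here means that more compound is needed for the effect, a lower number that less compound is needed), compound 3 gives > 36600 nM, which is a limit and not a number. It has no readable place among its relatives, and the whole set stands in the same position: the limit of > 36600 nM in this assay, at which 3 of the 3 values shown sit. No ranking of these compounds can therefore be made.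

The next compound is compound 4 `C=C[C@@](C)(/C=C/c1ccc(O)c(/C=C(\C)C(=O)OCC)c1)CCC=C(C)C`. The change is 2-(ethoxycarbonyl)prop-1-en-1-yl in place of 2-cyanoethenyl on an aromatic carbon, ortho to a hydroxy group.

Among the compounds with values here, only one measured step exists, a step that the two limits leave unreadable from compound 1 to compound 2, and it concerns a saturated chain carbon rather than the aromatic carbon that changes here. It offers no size to carry over, so no step beyond the scatter is expected in this assay, in either direction. The expectation leans instead on compound 3, with its > 36600 nM, a limit. The expected step is a step that the limit leaves unreadable from compound 3 to compound 4. The assay may well report only a limit again. Compound 4 is estimated at 40000 nM, with an expected range from 15000 nM to 80000 nM.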

Compound 4, half-maximal effective concentration: > 36600 nM
Compound 4 ended at the assay's limit (the forecaster's own chance of this, stated with the estimate: 70%); the middle value is on the limit's open side.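

Within the data shown here, compound 3 and compound 4 both sit at a limit rather than at a number, so no step between them can be read. The whole set stands in one position: the limit of > 36600 nM in this assay, at which 4 of the 4 values shown sit. The compounds shown leave open how far any of them lies beyond that limit in this assay, and whether 2-(ethoxycarbonyl)prop-1-en-1-yl in place of 2-cyanoethenyl changes the result at all.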